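A few compounds are considered here, and "the series" means these few. Any claim that something is new, unique, unknown or untested is made for them only; others in the source may bear on it.

In a functional assay for inhibition, with Homo sapiens as the target (on this read-out lower numbers stand for tighter binding and higher numbers for weaker binding), compound 1 (`O=C(O)CC/C=C\CC1COC(c2ccco2)OC1c1cccnc1`) gives 1260 nM, compound 2 (`COc1ccc(OC(C)(C)C2OCC(C/C=C\CCC(=O)O)C(c3cccnc3)O2)cc1`) gives 302 nM and compound 3 (`CC(C)(Oc1ccccc1F)C1OCC(C/C=C\CCC(=O)O)C(c2cccnc2)O1`) gives 166 nM. The number for compound 3 stands within the scatter of compound 2 and well under that of compound 1. Compound 4 (`CC(C)(Sc1ccccc1)C1OCC(C/C=C\CCC(=O)O)C(c2cccnc2)O1`) carries phenylsulfanyl in place of 2-fluorophenoxy on a saturated chain carbon bound to two saturated chain carbons and a saturated ring carbon. Within the data shown here, the one measured step that bears on this is a 1.8-fold lower number from compound 2 to compound 3 (0.26 log units; within the scatter), which alters only the group on the oxygen. Among the measured compounds shown here, no measured step replaces that oxygen with sulfur. No change beyond the scatter is therefore expected in this assay, and the expected step is a 1.2-fold higher number from compound 3 to compound 4 (0.08 log units; within the scatter). Compound 4 is estimated at 200 nM, with an expected range of 80 nM to 500 nM.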

Compound 4, dissociation constant: 200 nM
For compound 4 middle estimate and measured number coincide at the digits printed, within the range that was stated.
By their numbers in this assay, from the lowest: compounds 3, 4 and 2 (each within the scatter of the next); then compound 1.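

In this assay, the link through sulfur in phenylsulfanyl serves on this saturated chain carbon as well as the links through oxygen, with both steps within the scatter: a 1.2-fold higher number from compound 3 to compound 4 (0.08 log units; within the scatter) and a 1.5-fold lower number from compound 2 to compound 4 (0.18 log units; within the scatter). Among these compounds, the only step beyond the scatter is the exchange of a whole group on the saturated ring carbon, a 6.3-fold lower number from compound 1 to compound 4 (0.80 log units; beyond the scatter), and it is modest. Nothing measured here accounts for these results. As far as these compounds go, whether an amine in place of the sulfur would read alike stays open, as does the effect of a longer chain on that carbon.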